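Swapping a Nitro Group for a Hydroxyl on the Phenyl Ring

This account rests on a few compounds, and the source may have more. Where it says the series, first, only, none or still open, it means among the compounds named here.

Compound 3 `O=C1N=C(C2C(=O)c3ccccc3C2=O)CC(c2ccc([N+](=O)[O-])cc2)N1` was tested in a functional assay on the whole organism for inhibition, with Rattus norvegicus as the target, read by paw edema, with stated times of 30 min and 2 h, at a dose of 10 mg/kg by the oral route (on this read-out higher numbers stand for more inhibition at the one dose given (going by the name of the read-out) and lower numbers for less inhibition), where compound 3 gives 26%. Compound 1 `O=C1N=C(C2C(=O)c3ccccc3C2=O)CC(c2ccccc2)N1` gives 33% and compound 2 `COc1ccc(C2CC(C3C(=O)c4ccccc4C3=O)=NC(=O)N2)cc1` gives 21%; the steps of a number 7 percentage points lower from compound 1 to compound 3 (within the scatter) and a number 5 percentage points higher from compound 2 to compound 3 (within the scatter) both stay within the scatter, so compound 3 sits in the same band as both. Compound 4 `O=C1N=C(C2C(=O)c3ccccc3C2=O)CC(c2ccccc2O)N1` differs from compound 3 by 2-hydroxyphenyl in place of 4-nitrophenyl on a saturated ring carbon. Within the data shown here, no measured step exchanges these two groups. The nearest guides are a number 7 percentage points lower from compound 1 to compound 3 (within the scatter) and a number 12 percentage points lower from compound 1 to compound 2 (beyond the scatter), which show that placing a group on this phenyl ring changed the number little or lowered it modestly. For compound 4 a step within the scatter is therefore expected, a number 1 percentage points higher from compound 3 to compound 4 (within the scatter). Compound 4 is estimated at 27%, between 15% and 40%.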

Compound 4, a percentage reported as inhibition, in the whole organism at one dose (the size of the read-out at that dose, not a potency): 22%
Estimate against measurement, compound 4: 5 percentage points above, and the stated range covers the measured number.
By their numbers in this assay, from the lowest: compounds 2, 4, 3 and 1 (each within the scatter of the next, the first and the last beyond it).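

In this assay the three substituted phenyl rings cannot be told apart: 2-hydroxyphenyl in place of 4-nitrophenyl gives a number 4 percentage points lower from compound 3 to compound 4 (within the scatter) and in place of 4-methoxyphenyl gives a number 1 percentage points higher from compound 2 to compound 4 (within the scatter) in this series. Hydroxy in place of hydrogen gives a number 11 percentage points lower from compound 1 to compound 4 (beyond the scatter) and so, like methoxy, lowers the number beyond the scatter, whereas nitro stays within it. Nothing shown gives a reason for these numbers. Open, as far as these compounds go, is whether 4-hydroxyphenyl would match compound 4, and whether an amine or a carboxylic acid on this phenyl ring would reach the number of compound 1 or pass it.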